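This account rests on a few compounds, and the source may have more. Where it says the series, first, only, none or still open, it means among the compounds named here.

In a functional assay on SMMC-7721 cells (Homo sapiens) for antiproliferative activity, read by MTT assay, with a stated time of 48 h (on this read-out higher numbers stand for weaker inhibition and lower numbers for stronger inhibition), compound 3 `COCOC/C1=C/C[C@](C)(CCC=C(C)C)/C=C/[C@@H](OC(=O)C=C(C)C)[C@](C)(O)/C=C/C1=O` gives 3250 nM, the weakest inhibition of the three measured compounds, with compound 1 `CC(C)=CCC[C@]1(C)/C=C/[C@@H](OC(=O)C=C(C)C)[C@](C)(O)/C=C/C(=O)/C(CCl)=C\C1` at 840 nM and compound 2 `CC(C)=CCC[C@]1(C)/C=C/[C@@H](OC(=O)C=C(C)C)[C@](C)(O)/C=C/C(=O)/C(CN2CCCC2)=C\C1` at 140 nM. Compound 4 `CC(C)=CCC[C@]1(C)/C=C/[C@@H](OC(=O)C=C(C)C)[C@](C)(O)/C=C/C(=O)/C(C(=O)N2CCCC2)=C\C1` differs from compound 3 by a single change: (pyrrolidin-1-yl)carbonyl in place of (methoxymethoxy)methyl on a double-bonded ring carbon. The three measured steps all exchange a group on a saturated chain carbon bound to a double-bonded ring carbon. Of these, a 6.0-fold lower number from compound 1 to compound 2 (0.78 log units; beyond the scatter) and a 3.9-fold higher number from compound 1 to compound 3 (0.59 log units; beyond the scatter) are modest, while a 23-fold higher number from compound 2 to compound 3 (1.37 log units; beyond the scatter) is large. That large step bears most directly here, since compound 2 carries a pyrrolidin-1-yl group and compound 4 also carries that ring. However, in compound 4 the ring sits on a carbonyl, and no measured compound has this (pyrrolidin-1-yl)carbonyl group, so only a small part of that gap is expected to carry over. The expected change is a 1.8-fold lower number from compound 3 to compound 4 (0.26 log units; within the scatter), a modest move toward stronger inhibition that may not clear the scatter. For compound 4 the estimated value is 1800 nM, with an expected range from 500 nM to 6000 nM.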

Compound 4, half-maximal inhibitory concentration: 14900 nM
Estimate against measurement, compound 4: 8.3-fold (0.92 log units) below, and the stated range ends below it.
By their numbers in this assay, from the lowest: compound 2; then compound 1; then compound 3; then compound 4.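

In this assay, the same pyrrolidin-1-yl ring gives very different results depending on its link to the double-bonded ring carbon: replacing (pyrrolidin-1-yl)methyl with (pyrrolidin-1-yl)carbonyl gives a 110-fold higher number from compound 2 to compound 4 (2.03 log units; beyond the scatter), so the ring alone does not confer the stronger inhibition seen with compound 2. The carbonyl-linked group also compares poorly with the two groups lacking that ring, with a 4.6-fold higher number from compound 3 to compound 4 (0.66 log units; beyond the scatter) and an 18-fold higher number from compound 1 to compound 4 (1.25 log units; beyond the scatter), making compound 4 the weakest inhibitor of the four. Nothing available here accounts for this loss. The compounds shown leave open whether another amine on the methyl link, such as piperidin-1-ylmethyl or dimethylaminomethyl, would match compound 2. They also leave open whether a carboxylic acid at this ring carbon, or a carbonyl bearing a different amine, would behave like compound 4.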